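The compounds below may be only part of what the source reports. "The series", "measured", "known", "first", "only" and "open" are said of these compounds alone.

Compound 1 `CN1CCCc2c(NC(=O)c3ccc(-c4ccccc4)cc3)cccc21`: < 6.5 (a limit of the assay, not a number)
Compound 2 `CN1CCCc2ccc(NC(=O)c3ccc(-c4ccccc4)cc3)cc21`: 7.5

In a functional assay for antagonist activity at transient receptor potential cation channel subfamily V member 1 (Homo sapiens), read by FLIPR and calcium flux (on this read-out higher numbers stand for higher potency (the scale is a negative logarithm) and lower numbers for lower potency), compound 1 reaches only the limit of the assay, < 6.5 (the limit of < 6.5 in this assay, at which 1 of the 2 values shown sits). Compound 2 holds the only real number shown so far, 7.5. The next compound, compound 3 `O=C(Nc1ccc2c(c1)NCCC2)c1ccc(-c2ccccc2)cc1`, is not yet measured; it differs from compound 2 in one place: hydrogen in place of methyl on a nitrogen on an aromatic ring in a ring. Going by the values given here, no measured pair of this kind exists here to lean on, so the step from compound 2 to compound 3 is expected to be small, near the scatter, with a slight fall as the more likely direction: a number 0.30 log units lower from compound 2 to compound 3 (within the scatter). Compound 3 is therefore estimated at 7.2, in a range from 6.5 to 7.9.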

Compound 3, negative logarithm of the antagonist equilibrium constant: 7.7
For compound 3 the middle estimate is 0.50 log units below the measured one; low and high end bracket the measured number.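

Putting hydrogen in place of methyl on the nitrogen of the six-membered non-aromatic ring gives a number 0.20 log units higher from compound 2 to compound 3 (within the scatter) in this assay. Going by these compounds alone, this is the first view of this position, and it shows that in this pair the methyl can be removed without a change that stands out from the scatter. Nothing measured here offers a reason for this result.

The compounds shown leave open what a longer chain such as propyl, or an acetyl group, would do on this nitrogen. One pair also cannot show whether the same holds on other cores.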